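Butyl to 4-bromophenyl on the ring nitrogen

The compounds below may be only part of what the source reports. "The series", "measured", "known", "first", "only" and "open" are said of these compounds alone.

In a functional assay on MDA-MB-468 cells (Homo sapiens) for antiproliferative activity, read by MTT assay, with a stated time of 72 h (on this read-out higher numbers stand for weaker inhibition and lower numbers for stronger inhibition), compound 1 (`CCCCn1ccnc1-c1cc(OC)c(OC)c(OC)c1`) gives 44100 nM. Compound 3 (`COc1cc(-c2nccn2-c2ccc3sccc3c2)cc(OC)c1OC`) gives 400 nM, which leaves compound 1 with the higher of the two numbers. Compound 2 (`COc1cc(-c2nccn2S(=O)(=O)c2ccc(C)cc2)cc(OC)c1OC`) returns only a limit, > 100000 nM.

Compound 4 (`COc1cc(-c2nccn2-c2ccc(Br)cc2)cc(OC)c1OC`) has 4-bromophenyl in place of butyl on an aromatic nitrogen. Among the compounds with values here, no measured step isolates this change. A step to a lower number in this assay, beyond the scatter, is expected since compound 3, which also carries an aromatic ring on that nitrogen, gives 400 nM. The expected step runs an 18-fold lower number from compound 1 to compound 4 (1.25 log units; beyond the scatter). The estimate for compound 4 is 2500 nM, with an expected range from 400 nM to 15000 nM.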

Compound 4, half-maximal inhibitory concentration: 2700 nM
Estimate against measurement, compound 4: 1.1-fold (0.03 log units) below, and the stated range covers the measured number.
By their numbers in this assay, from the lowest: compound 3; then compound 4; then compound 1. At a limit, above all of these: compound 2.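

In this assay, within the data shown here, 4-bromophenyl in place of butyl on the aromatic nitrogen gives a 16-fold lower number from compound 1 to compound 4 (1.21 log units; beyond the scatter) as the only step read at a single place. An aromatic ring on that nitrogen is thereby tied to the lower number by a direct comparison, for this one pair of compounds.

Open, on these data alone, is how much of the step belongs to the bromine and how much to the ring itself, which plain phenyl or cyclohexyl on that nitrogen would separate. Nothing given here points to a cause for the step.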